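The source may report more compounds than this note shows. Statements on the series, on what has been measured and on what is new or still open speak of the compounds shown alone.

Measured so far in this series:

Compound 1, `O=C(NO)c1ccc(-c2cn([C@@H]3C[C@H](C(=O)O)N(CCCc4ccccc4)C3)nn2)cc1`, gives a limit, < 10%.
Compound 2, `O=C(/C=C/c1cn([C@@H]2C[C@H](C(=O)O)N(CCCc3ccccc3)C2)nn1)NO`, gives 11%.
Compound 3, `O=C(/C=C/c1cn([C@H]2C[C@H](C(=O)O)N(Cc3ccccc3)C2)nn1)NO`, gives 14%.

All three were tested in an assay on Sf9 cells for inhibition of histone deacetylase 11 (Homo sapiens), read by fluorescence, tested at 0.5 uM; on this read-out lower numbers stand for less inhibition and higher numbers for more inhibition at the one concentration tested (going by the name of the read-out). The value of compound 1 is a limit of the assay rather than a number, as the limit of < 10% in this assay, at which 1 of the 3 values shown sits, records. Compound 2 and compound 3 sit within the usual scatter of each other, so their numbers are not told apart here. The cores of compound 2 and compound 3 differ, but that difference is not broken down here.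

One structural change occurs twice among these compounds: 4-(hydroxycarbamoyl)phenyl in place of 2-(hydroxycarbamoyl)ethenyl on an aromatic carbon. Between the measured pair it gave a number at least 1 percentage points lower from compound 2 to compound 1 (that floor lies within the scatter). Compound 4, `O=C(NO)c1ccc(-c2cn([C@H]3C[C@H](C(=O)O)N(Cc4ccccc4)C3)nn2)cc1`, carries the same change from compound 3, namely (4-(hydroxycarbamoyl)phenyl in place of 2-(hydroxycarbamoyl)ethenyl on an aromatic carbon), at the same place.

Resting on the step from compound 2 to compound 1 in this assay, the step from compound 3 to compound 4 is expected to be about a number 4 percentage points lower from compound 3 to compound 4 (within the scatter). Compound 4 is therefore estimated at 10%, with a range from 3% to 17%, and the assay may well report only a limit.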

Compound 4, a percentage reported as inhibition, at one concentration (the size of the read-out at that concentration, not a potency): < 10%
Compound 4: no number, only a limit (the forecaster's own chance of this, stated with the estimate: 45%); the middle value lies on the limit itself.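

In this assay compound 4 gives < 10%, which is a limit of the assay and not a number. Placing 4-(hydroxycarbamoyl)phenyl on the aromatic carbon in place of 2-(hydroxycarbamoyl)ethenyl gives a number at least 4 percentage points lower from compound 3 to compound 4 (that floor lies within the scatter), and the two steps can be compared only as floors: the same change on two cores in this assay, a number at least 1 percentage points lower (that floor lies within the scatter) from compound 2 to compound 1 and a number at least 4 percentage points lower (that floor lies within the scatter) from compound 3 to compound 4; the limit leaves it open whether they differ This shows that the change takes both cores to the same limit, but it does not show that the change has the same size on each core, and no size can be read for either step from values at this limit: the limit of < 10% in this assay, at which 2 of the 4 values shown sit.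

The compounds shown leave open how the 4-(hydroxycarbamoyl)phenyl change would behave on a core whose ethenyl compound reads well clear of the limit. They also leave open what an ester or an amide in place of the carboxylic acid would do to the reading in this assay.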